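Chloro on the benzoyl ring of compound 3

This account rests on a few compounds, and the source may have more. Where it says the series, first, only, none or still open, it means among the compounds named here.

The series is read in a functional assay on DLD-1 cells (Homo sapiens); on this read-out lower numbers stand for stronger inhibition and higher numbers for weaker inhibition. Compound 1 `CC(C)C/N=C(\S)N1CCN(c2ccc(N(Cc3c[nH]cn3)S(=O)(=O)c3ccccc3)cc2)CC1` gives 800 nM, and compound 2 `O=S(=O)(c1ccccc1)N(Cc1c[nH]cn1)c1ccc(N2CCN(C(=S)NC3CCCCC3)CC2)cc1` gives 1000 nM; the step of a 1.3-fold higher number from compound 1 to compound 2 (0.10 log units; within the scatter) concerns the group on the thiourea and is within the scatter. Compound 3 `N#Cc1ccc(Cn2cncc2CN(C(=O)c2ccccc2)c2ccc(N3CCN(C(=O)c4ccc(Cl)s4)CC3)cc2)cc1`, with amide groups in place of the thiourea and a different core, gives 3 nM, the lowest number of the three; the gaps to compound 1 and to compound 2 lie beyond the scatter.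

Compound 4 `N#Cc1ccc(Cn2cncc2CN(C(=O)c2cccc(Cl)c2)c2ccc(N3CCN(C(=O)c4ccc(Cl)s4)CC3)cc2)cc1` differs from compound 3 in one place: chloro in place of hydrogen on an aromatic carbon, meta to a large group on the benzoyl ring. Among the compounds with values here, none of the measured steps touches this ring; the only one-place step known, from the thiourea substituent of compound 1 to that of compound 2, is on another part of the molecule and gives no lead for a substituent on the benzoyl phenyl. The expectation therefore rests on the value of compound 3 alone and is a step of no change at the digits printed from compound 3 to compound 4 (within the scatter) of no clear direction beyond the scatter. Compound 4 is expected to give about 3 nM, within a range from 1 nM to 10 nM.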

Compound 4, half-maximal inhibitory concentration: 2 nM
Beside the measured number, compound 4's estimate is 1.5-fold (0.18 log units) above it; the measured number falls inside the stated range.
By their numbers in this assay, from the lowest: compounds 4 and 3 (each within the scatter of the next); then compounds 1 and 2 (each within the scatter of the next).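

The step on the benzoyl ring reads a 1.5-fold lower number from compound 3 to compound 4 (0.18 log units; within the scatter) in this assay, so chloro in place of hydrogen on this aromatic carbon, meta to a large group, gives no change that can be told apart from repeat scatter. Within the data shown here, this is the first reading for any substituent on this ring, since the only earlier one-place step lay on the thiourea group, and it shows that this position can carry a chloro with the number staying within the scatter of the unsubstituted phenyl. Nothing available on the compounds bears on why the number behaves this way, and the step is recorded here without any explanation.

From the compounds shown here alone, a single chloro at a single position says little about the ring as a whole: whether a larger or differently built group here, such as a methoxy, an amine or a carboxylic acid, or a chloro on another ring carbon, would also stay within the scatter remains open. The wide gap between compound 3 and the thioureas also stays unassigned, as those compounds differ from it in more than one place.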